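A few compounds are considered here, and "the series" means these few. Any claim that something is new, unique, unknown or untested is made for them only; others in the source may bear on it.

Measured compounds in an assay on isolated protein for inhibition of homeodomain-interacting protein kinase 1 (Homo sapiens), read by polymerase chain reaction, with a stated time of 1 h; a lower number here means a stronger inhibitor, a higher number a weaker inhibitor:
- compound 1 `O=S(=O)(NCCCNc1nccc(-c2c(-c3cccc(O)c3)nc3sccn23)n1)c1cccc(F)c1`: 4880 nM
- compound 2 `O=S(=O)(NCCNc1nccc(-c2c(-c3cccc(O)c3)nc3sccn23)n1)c1ccc(F)cc1`: 5130 nM
- compound 3 `COc1cccc(-c2nc3sccn3c2-c2ccnc(NCCNS(=O)(=O)c3ccc(C(F)(F)F)cc3)n2)c1`: 4580 nM

Compound 1 gives the second highest of the three numbers in this assay; its nearest neighbour is compound 2 and its furthest is compound 3, and both gaps lie within the scatter. Within the data shown here, the only single-point step available, a 1.1-fold higher number from compound 1 to compound 2 (0.02 log units; within the scatter), is likewise within the scatter, so nothing among the measured pairs separates one compound from another.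

Compound 4 `COc1cccc(-c2nc3sccn3c2-c2ccnc(NCCCNS(=O)(=O)c3cccc(F)c3)n2)c1` differs from compound 1 by methyl in place of hydrogen on an oxygen on an aromatic ring. Among the measured compounds shown here, no measured step isolates this change. Compound 3 carries the methoxy group, but also a different sulfonyl part and chain, so its value can only be read alongside that of compound 1, and the two numbers lie within the scatter of each other. On that basis the expectation for this assay is no step beyond the scatter, with a 1.0-fold higher number from compound 1 to compound 4 (0.00 log units; within the scatter) expected as essentially flat. Compound 4 is therefore estimated at 4900 nM, with a range of 2000 nM to 12000 nM.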

Compound 4, half-maximal inhibitory concentration: 3840 nM
Estimate against measurement, compound 4: 1.3-fold (0.11 log units) above; low and high end bracket the measured number.
By their numbers in this assay, from the lowest: compounds 4, 3, 1 and 2 (each within the scatter of the next).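

In this assay, the change from 3-hydroxyphenyl to 3-methoxyphenyl now has a direct reading on an otherwise unchanged structure, with a 1.3-fold lower number from compound 1 to compound 4 (0.10 log units; within the scatter). In this pair, the hydrogen on the oxygen can therefore give way to methyl without a shift beyond the scatter, so the free hydroxy is not needed to hold the number at this level. Nothing available explains this flat step.

Going by these compounds, it remains open whether this place tolerates groups beyond hydroxy and methoxy, such as an amine, a carboxylic acid or a longer ethoxy chain on the oxygen. On these data alone, it is also open whether any such group could move the number beyond the scatter, or whether the same change would stay flat with a different sulfonyl part.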